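Replacing the 4-fluorophenyl of compound 1 with an indolyl

The compounds below may be only part of what the source reports. "The series", "measured", "known", "first", "only" and "open" are said of these compounds alone.

Compound 1 `COc1cc(-c2ccnc3cc(-c4ccc(F)cc4)nn23)cc(OC)c1OC` gives 3800 nM in a functional assay on A549 cells (Homo sapiens) for inhibition, read by CCK-8 assay, with a stated time of 48 h (on this read-out lower numbers stand for stronger inhibition and higher numbers for weaker inhibition), the highest of the three numbers measured. Compound 2 `COc1cc(-c2ccnc3cc(-c4ccc(C)cc4)nn23)cc(OC)c1OC` gives 3 nM and compound 3 `COc1cc(-c2ccnc3cc(-c4ccc(N(C)C)cc4)nn23)cc(OC)c1OC` gives 1100 nM in this assay; compound 1 sits nearest to compound 3 and furthest from compound 2.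

Compound 4 `COc1cc(-c2ccnc3cc(-c4ccc5ccn(C)c5c4)nn23)cc(OC)c1OC` is not yet measured. It differs from compound 1 by 1-methyl-1H-indol-6-yl in place of 4-fluorophenyl on an aromatic carbon. Two measured steps start from the same fluoro of compound 1: a 1300-fold lower number from compound 1 to compound 2 (3.10 log units; beyond the scatter) and a 3.5-fold lower number from compound 1 to compound 3 (0.54 log units; beyond the scatter). Both replacements of the fluoro lowered the number, one by a large step, the other by a modest one, and the step of a 370-fold higher number from compound 2 to compound 3 (2.56 log units; beyond the scatter) shows how far the two substituents diverge. The 1-methyl-1H-indol-6-yl is a fused group unlike either, so a lower number than compound 1 is expected, with its size uncertain. For compound 4 the expected step in this assay is a 19-fold lower number from compound 1 to compound 4 (1.28 log units; beyond the scatter). Compound 4 is thus estimated at 200 nM, with a range from 10 nM to 3000 nM.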

Compound 4, half-maximal inhibitory concentration: 829 nM
Beside the measured number, compound 4's estimate is 4.1-fold (0.62 log units) below it; the measured number falls inside the stated range.
By their numbers in this assay, from the lowest: compound 2; then compounds 4 and 3 (each within the scatter of the next); then compound 1.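

In this assay the larger fused 1-methyl-1H-indol-6-yl is tolerated at this position, with a 4.6-fold lower number from compound 1 to compound 4 (0.66 log units; beyond the scatter), but it stays far from the 4-methylphenyl group, with a 280-fold higher number from compound 2 to compound 4 (2.44 log units; beyond the scatter). With a 1.3-fold lower number from compound 3 to compound 4 (0.12 log units; within the scatter), compound 4 and compound 3 cannot be separated, although 1-methyl-1H-indol-6-yl is a fused group and 4-(dimethylamino)phenyl is not. Among the four compounds, compound 2 stands alone at the low end, and nothing available explains its separation from the other three.

On these data alone, it remains open whether an ethyl, a methoxy or a chloro in place of the methyl of compound 2 would keep a number close to that of compound 2. The unmethylated 1H-indol-6-yl also leaves open what the methyl on the indole nitrogen contributes.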